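Thiourea and cyanoguanidine side chains in this series

The source may report more compounds than this note shows. Statements on the series, on what has been measured and on what is new or still open speak of the compounds shown alone.

Measured compounds and their values:
Compound 1, `CC/N=C(/NC#N)NCCCCn1nc(-c2ccccc2)c(C)cc1=O`, gives in a functional assay on the whole organism (stomach) with Rattus norvegicus as the target (a lower number here means that less compound is needed, a higher number that more compound is needed for the effect), a value that is a limit of the assay, > 100 mg/kg.
Compound 2, `C/N=C(/NC#N)NCCCCn1nc(-c2ccccc2)c(C)cc1=O`, gives in this assay a value that is also a limit, > 100 mg/kg.
Compound 3, `CC/N=C(\S)NCCCn1nc(-c2ccccc2)ccc1=O`, gives in this assay a value that is a limit as well, > 100 mg/kg.

Among the compounds with values here, compound 3 stands at the limit that all three measured compounds share; no number has been obtained for any of them, and the only recorded step, a step that the two limits leave unreadable from compound 1 to compound 2, is unreadable because both ends are limits. The common ground across the measured set is the limit of > 100 mg/kg in this assay, at which 3 of the 3 values shown sit.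

Compound 4, `N/C(S)=N/CCCCn1nc(-c2ccccc2)ccc1=O`, is the next compound to be measured in this assay. It differs from compound 3 by a group of 5 heavy atoms (2 carbon, 2 nitrogen, 1 sulfur; no ring) in place of a group of 6 heavy atoms (3 carbon, 2 nitrogen, 1 sulfur; no ring), on a saturated chain carbon, three bonds along the chain from an aromatic nitrogen. Within the data shown here, the one measured step, a step that the two limits leave unreadable from compound 1 to compound 2, is the only change of comparable kind and yields no size, so there is no measured step that bears on the present change in a readable way.

With all three measured values sitting at the limit, compound 4 is expected to give a value near that limit, and most likely a limit again rather than a number. The expected step that the limit leaves unreadable from compound 3 to compound 4 is therefore an estimate of no change beyond the scatter. The estimate for compound 4 in this assay is 150 mg/kg, with a range from 50 mg/kg to 500 mg/kg.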

Compound 4, dose for half-maximal effect: 36.3 mg/kg
Compound 4: the middle estimate sits 4.1-fold (0.62 log units) above what was measured, outside the stated range (below it).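

In this assay, within the data shown here, the change on a saturated chain carbon, three bonds along the chain from an aromatic nitrogen, gives the first step that can be read: the group of 5 heavy atoms (2 carbon, 2 nitrogen, 1 sulfur; no ring) in place of the group of 6 heavy atoms (3 carbon, 2 nitrogen, 1 sulfur; no ring) yields an at least 2.7-fold lower number from compound 3 to compound 4 (0.44 log units; beyond the scatter). Compound 4 is also the only compound shown with a number rather than a limit, so a thiourea side chain at this place can give a measurable effect on the shared core. The earlier step between the two cyanoguanidines cannot be read, and the rest of the set stays where it was: the limit of > 100 mg/kg in this assay, at which 3 of the 4 values shown sit.

The compounds shown do not separate the parts of the change from compound 3, so it remains open which part of the group carries the step. Also open, from the compounds shown here alone, is how this assay would read for an amine or a carboxylic acid at the end of the side chain, or for a longer chain carrying the group of compound 4.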